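A few compounds are considered here, and "the series" means these few. Any claim that something is new, unique, unknown or untested is made for them only; others in the source may bear on it.

Of the compounds shown here, two with a shared core have been measured in an assay on cells for displacement of a labelled ligand from corticotropin-releasing factor receptor 1 (Homo sapiens), with a stated time of 100 min; on this read-out higher numbers stand for weaker inhibition and lower numbers for stronger inhibition. Compound 1 `CCCCN(CC)Cc1c(C(F)(F)F)nc2n(-c3c(C)cc(C)cc3C)c(Cl)cn12` gives 78 nM in this assay. Compound 2 `CCCN(Cc1ccc([N+](=O)[O-])cc1)Cc1c(C(F)(F)F)nc2n(-c3c(C)cc(C)cc3C)c(Cl)cn12` gives 150 nM in this assay. Compound 1 has the lower of the two numbers, but the gap to compound 2 lies within the scatter of repeated measurements, so the two cannot be ranked against each other.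

Compound 3 `Cc1cc(C)c(-n2c(Cl)cn3c(CN(C)Cc4ccco4)c(C(F)(F)F)nc23)c(C)c1` has not yet been measured in this assay. It differs from compound 1 in one place: ((furan-2-yl)methyl)(methyl)amino in place of butyl(ethyl)amino on a saturated chain carbon bound to an aromatic carbon. Among the compounds with values here, no pair of measured compounds shows the effect of a change of this kind, so the expectation rests only on the two values at hand, which sit close together. The step from compound 1 to compound 3 is expected to be small, if anything toward a higher number, and likely within the scatter a 1.5-fold higher number from compound 1 to compound 3 (0.19 log units; within the scatter). Compound 3 is therefore estimated to give 120 nM in this assay, with a range from 40 nM to 400 nM.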

Compound 3, inhibition constant: 180 nM
Compound 3: middle estimate off by 1.5-fold (0.18 log units), on the low side; low and high end bracket the measured number.
By their numbers in this assay, from the lowest: compounds 1, 2 and 3 (each within the scatter of the next, the first and the last beyond it).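

In this assay, within the data shown here, this is the first step between compounds that differ in one place, and it shows that the read-out responds to the amine on a saturated chain carbon bound to an aromatic carbon. Putting ((furan-2-yl)methyl)(methyl)amino in place of butyl(ethyl)amino gives a 2.3-fold higher number from compound 1 to compound 3 (0.36 log units; beyond the scatter), a modest change that leaves binding still measurable with a five-membered aromatic ring in the group. Nothing at hand explains why the number moves in this direction.

Both chains on the amine nitrogen change at once, and the compounds shown do not tell how much of the step belongs to the furan ring and how much to the methyl group. Also open, going by these compounds, is how a thiophene ring in place of the furan, or a morpholine ring as the whole amine, would read at this position.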